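Adding a Methyl to an Amide Nitrogen

The source may report more compounds than this note shows. Statements on the series, on what has been measured and on what is new or still open speak of the compounds shown alone.

Compound 1 `CNC(=O)CNCc1ccc(OCc2cccc(Cl)c2)cc1`: 48.6 mg/kg
Compound 2 `C[C@@H](NCc1ccc(OCc2ccccc2)cc1)C(N)=O`: 17.1 mg/kg

In a functional assay on the whole organism with Mus musculus as the target, in the maximal electroshock model (on this read-out higher numbers stand for an effect only at larger amounts of compound and lower numbers for an effect already at smaller amounts), compound 2 gives 17.1 mg/kg, the lower of the two numbers, and the gap to compound 1 lies beyond the usual scatter. Lower numbers here mean that a smaller amount of compound is enough.

Compound 3 `CNC(=O)[C@@H](C)NCc1ccc(OCc2ccccc2)cc1` differs from compound 2 by methyl in place of hydrogen on an amide-type nitrogen. Within the data shown here, no measured pair shows this change alone, so the expectation is uncertain. A small rise in the number, within the scatter, is expected: a 1.8-fold higher number from compound 2 to compound 3 (0.24 log units; within the scatter). Compound 3 is estimated at 30 mg/kg, with an expected range of 13 mg/kg to 70 mg/kg.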

Compound 3, dose for half-maximal effect: 7 mg/kg
Estimate against measurement, compound 3: 4.3-fold (0.63 log units) above; measured number outside the range, below it.
By their numbers in this assay, from the lowest: compound 3; then compound 2; then compound 1.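

The amide hydrogen of compound 2 can be replaced: in this assay, methyl on this amide-type nitrogen gives a 2.4-fold lower number from compound 2 to compound 3 (0.39 log units; beyond the scatter), so a smaller amount of compound is enough. Among these compounds, this single pair is the first to show this change alone, and it shows the change lowering the number rather than raising it. Nothing at hand says why the number falls. As far as these compounds go, whether an ethyl group or a longer chain on this nitrogen would lower the number further remains open. So does the effect of two methyl groups there, which would leave no amide hydrogen.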